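Diester series: replacing the propyl ester chain

The source may report more compounds than this note shows. Statements on the series, on what has been measured and on what is new or still open speak of the compounds shown alone.

Three compounds of the shared core have numbers in an assay on CHO cells for inhibition of metabotropic glutamate receptor 1 (Rattus norvegicus); a lower number here means a stronger inhibitor, a higher number a weaker inhibitor. Compound 2 `CCCOC(=O)c1[nH]cc(C(=O)OC(C)C(C)(C)C)c1C` gives 4 nM, the lowest of the three. Compound 1 `Cc1c(C(=O)OC(C)(C)C)c[nH]c1C(=O)OC(C)(C)C` gives 100 nM in this assay, and compound 3 `CCCOC(=O)c1[nH]c(COC(C)=O)c(C(=O)OC(C)(C)C)c1C` gives 2700 nM; both gaps to compound 2 lie beyond the scatter, so compound 2 stands as the strongest inhibitor of the three measured. No pair among these three differs in one place only, so no single step is isolated from the measured data.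

Compound 4 `Cc1c(C(=O)OC(C)C(C)(C)C)c[nH]c1C(=O)OC(C)CN(C)C` is the next point, not yet measured in this assay. It differs from compound 2 in one place: 1-((dimethylamino)methyl)ethyl in place of propyl on an oxygen next to a carbonyl group. Nothing measured in the series speaks to this kind of exchange on the ester oxygen, so the expectation rests only on the size of the change and on the strong starting point of compound 2 at 4 nM. A moderate loss is expected, with the step from compound 2 to compound 4 estimated at a 10-fold higher number from compound 2 to compound 4 (1.00 log units; beyond the scatter). For compound 4 the estimate in this assay is 40 nM, with a range from 8 nM to 300 nM.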

Compound 4, half-maximal inhibitory concentration: 390 nM
Compound 4: middle estimate off by 9.8-fold (0.99 log units), on the low side; measured number above the stated range.
By their numbers in this assay, from the lowest: compound 2; then compound 1; then compound 4; then compound 3.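

The first step isolated in this series shows that the propyl on the ester oxygen of compound 2 does not tolerate every exchange: in this assay, the step of a 98-fold higher number from compound 2 to compound 4 (1.99 log units; beyond the scatter) is large and lies beyond the scatter. The entering 1-((dimethylamino)methyl)ethyl brings 6 heavy atoms, including 1 nitrogen, where propyl has 3 heavy atoms and no nitrogen, so this one position alone can carry a large change in the number. No measured evidence bears on why the step is this large.

Still open, as far as these compounds go, is whether the loss follows the nitrogen or the larger chain, which a plain pentyl chain on the same oxygen would help separate. Also open, from the compounds shown here alone, is whether a shorter chain ending in a dimethylamino group, or one ending in a carboxylic acid, would behave in the same way.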